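The source may report more compounds than this note shows. Statements on the series, on what has been measured and on what is new or still open speak of the compounds shown alone.

Measured in a functional assay on HCT-116 cells (Homo sapiens) for antiproliferative activity, read by MTT assay, with a stated time of 72 h; a lower number here means a stronger inhibitor, a higher number a weaker inhibitor:

Compound 1 `O=C(CCc1cccc2c1B(O)OC2)Nc1cccc(-c2cccc(F)c2)c1`: 460 nM
Compound 2 `O=C(CCc1cccc2c1B(O)OC2)Nc1cccc(-c2cccc(Cl)c2)c1`: 350 nM

Compound 2, at 350 nM, cannot be separated from compound 1, at 460 nM, since the two numbers lie within the ordinary scatter of repeated measurements. Together they are the only reference points so far. The next compound to be tested, compound 3 `O=C(CCc1cccc2c1B(O)OC2)Nc1cccc(-c2ccc(Cl)cc2)c1`, has the same atoms as compound 2, joined differently: 4-chlorophenyl in place of 3-chlorophenyl on an aromatic carbon. In short, the chloro group stays but its phenyl ring changes from 3-chlorophenyl to 4-chlorophenyl.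

Among the compounds with values here, only one measured step is available for comparison: a 1.3-fold lower number from compound 1 to compound 2 (0.12 log units; within the scatter). That step exchanged fluoro for chloro on an aromatic carbon and left the group's place unchanged, so it bears on this question only indirectly. Within the data shown here, no measured pair shows what a change of place does here. The expectation is therefore no change beyond the scatter, held with caution. The expected step is a 1.1-fold higher number from compound 2 to compound 3 (0.06 log units; within the scatter). For compound 3 the estimated value is 400 nM, with an expected range from 150 nM to 1100 nM.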

Compound 3, half-maximal inhibitory concentration: 380 nM
Compound 3: middle estimate off by 1.1-fold (0.02 log units), on the high side; the range from low to high includes it.
By their numbers in this assay, from the lowest: compounds 2, 3 and 1 (each within the scatter of the next).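

Putting 4-chlorophenyl in place of 3-chlorophenyl on the shared core gives a 1.1-fold higher number from compound 2 to compound 3 (0.04 log units; within the scatter) in this assay. This is the only pair shown in which the chlorine moves while the atoms stay the same, and it offers no sign that these two places can be told apart in this assay. Compound 3 also cannot be separated from compound 1, with a 1.2-fold lower number from compound 1 to compound 3 (0.08 log units; within the scatter), even though that pair differs in both the halogen and its place on the ring, and nothing measured here speaks to why the three numbers lie so close together.

As far as these compounds go, all three compounds carry a single halogen on this outer phenyl ring, so it remains open whether the same closeness would hold for a ring bearing a methoxy group, an amine or a carboxylic acid, or for a phenyl ring with no substituent at all. The compounds also share the same chain between the carbonyl and the core, which leaves open what a longer chain would do to the number in this assay.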